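The compounds below may be only part of what the source reports. "The series", "measured", "known", "first", "only" and "open" are said of these compounds alone.

Measured compounds:
Compound 1 `CCCOC(=O)N1CCN(/[N+]([O-])=N/Oc2cc(O/N=[N+](\[O-])N(C)C)c([N+](=O)[O-])cc2[N+](=O)[O-])CC1`: 1600 nM
Compound 2 `CCN(CC)C(=O)N1CCN(/[N+]([O-])=N/Oc2cc(O/N=[N+](\[O-])N(C)C)c([N+](=O)[O-])cc2[N+](=O)[O-])CC1`: 1900 nM

Both numbers come from a functional assay on HL-60 cells (Homo sapiens) for antiproliferative activity, read by MTT assay, with a stated time of 72 h; a lower number here means a stronger inhibitor, a higher number a weaker inhibitor. On the two numbers shown, compound 2 has the higher one, and its nearest neighbour is compound 1, but the step of a 1.2-fold higher number from compound 1 to compound 2 (0.07 log units; within the scatter) is within the scatter, so the two compounds cannot be told apart on these data.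

Compound 3 `CN(C)/[N+]([O-])=N/Oc1cc(O/N=[N+](\[O-])N2CCN(c3ncccn3)CC2)c([N+](=O)[O-])cc1[N+](=O)[O-]` differs from compound 2 in the following way: pyrimidin-2-yl in place of diethylcarbamoyl on an amine nitrogen in a ring. Among the compounds with values here, only one measured step exists, the one from compound 1 to compound 2, and it concerns the group on a carbonyl carbon rather than a replacement of the whole group on the ring nitrogen. Its size, a 1.2-fold higher number from compound 1 to compound 2 (0.07 log units; within the scatter), was within the scatter. That step bears on the present change only in showing that the shared core of compound 1 tolerated a change at this end of the molecule without a shift beyond the scatter. Within the data shown here, no measured step covers an aromatic ring in this place. On that basis the step from compound 2 to compound 3 is expected to be small, a 1.1-fold lower number from compound 2 to compound 3 (0.05 log units; within the scatter), with a wide range to reflect the lack of a directly comparable step. The estimate for compound 3 in this assay is 1700 nM, expected to fall between 500 nM and 6000 nM.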

Compound 3, half-maximal inhibitory concentration: 1200 nM
Compound 3: middle estimate off by 1.4-fold (0.15 log units), on the high side; the measured number falls inside the stated range.
By their numbers in this assay, from the lowest: compounds 3, 1 and 2 (each within the scatter of the next).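

Until now, only the group on a carbonyl carbon had changed at this end of the molecule. Compound 3 removes that carbonyl and places an aromatic ring with two hetero atoms directly on the amine nitrogen in the ring. In this assay, neither replacement can be told apart from the scatter: pyrimidin-2-yl in place of diethylcarbamoyl gives a 1.6-fold lower number from compound 2 to compound 3 (0.20 log units; within the scatter), and pyrimidin-2-yl in place of propoxycarbonyl gives a 1.3-fold lower number from compound 1 to compound 3 (0.12 log units; within the scatter), so across these three compounds the carbonyl is not needed to keep the number in the same range. Nothing available on these compounds bears on why the three numbers stay so close together.

The compounds shown leave open whether any group on this amine nitrogen would shift the number beyond the scatter, since all three carry a fairly large group there; a plain hydrogen, a methyl, a chain ending in a carboxylic acid or a chain ending in an amine would test this. They also leave open whether a benzene ring or a pyridine ring would behave as pyrimidin-2-yl does here.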